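The source may report more compounds than this note shows. Statements on the series, on what has been measured and on what is new or still open speak of the compounds shown alone.

Measured so far:
Compound 1, `CCCCCCNc1ccc([N+](=O)[O-])cc1S(N)(=O)=O`. In an ADME assay on microsomes from liver (Mus musculus) for metabolic stability, tested at 5 uM (on this read-out higher numbers stand for a longer-lived compound and lower numbers for a shorter-lived compound), compound 1 gives < 0.0834 h, which is a limit of the assay and not a number.
Compound 2, `CCCCCCCCNc1ccc([N+](=O)[O-])cc1S(N)(=O)=O`. In this assay compound 2 gives < 0.0834 h, again a limit of the assay rather than a number.
Compound 3, `CCCCCCNc1ccc(C(=O)O)cc1S(=O)(=O)NC`. In this assay, for the measured compounds named here, compound 3 gives 0.483 h, the only plain number in the set.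

Compound 4, `CCCCCCCCNc1ccc(C(=O)O)cc1S(=O)(=O)NC`, has not yet been measured in this assay. It differs from compound 3 by ethyl in place of hydrogen on a saturated chain carbon, six bonds along the chain from a nitrogen on an aromatic ring. The same change is made between the two measured compounds, (ethyl in place of hydrogen on a saturated chain carbon, six bonds along the chain from a nitrogen on an aromatic ring), but the step it made there, a step that the two limits leave unreadable from compound 1 to compound 2, cannot be read, because both ends sit at the limit of < 0.0834 h in this assay, at which 2 of the 3 values shown sit. The change from compound 1 to compound 2 and the change from compound 3 to compound 4 are the same, place and all. How the core of compound 3 differs from the core of compound 1 is not broken down here.

So the measured pair says nothing about the direction or size of the step, and the expectation for compound 4 rests on the value of compound 3 alone, 0.483 h, with the change allowed some room to move it either way. The step from compound 3 to compound 4 is estimated at a 1.6-fold lower number from compound 3 to compound 4 (0.21 log units; within the scatter). Compound 4 is therefore expected to give about 0.3 h in this assay, with a likely range from 0.1 h to 0.8 h.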

Compound 4, half-life: 0.2 h
Compound 4: the middle estimate sits 1.5-fold (0.18 log units) above what was measured, within the range that was stated.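

In this assay, putting ethyl in place of hydrogen on a saturated chain carbon, six bonds along the chain from a nitrogen on an aromatic ring, gives a 2.4-fold lower number from compound 3 to compound 4 (0.38 log units; beyond the scatter), a modest step on the core of compound 3. The same change on the core of compound 1 cannot be read, because both compounds of that pair stand at a limit of the assay rather than at a number: the limit of < 0.0834 h in this assay, at which 2 of the 4 values shown sit. The series therefore offers one readable step on one core and no test of carrying it to another, so a similar drop on the core of compound 1 is neither supported nor excluded.

On these data alone, it remains open whether a longer chain on the core of compound 3 would take the half-life lower still, whether a shorter chain such as butyl would lengthen it, and what an amine or a hydroxyl group at the end of the chain would do. Also open, as far as these compounds go, is how the same change would read on the core of compound 1 with a carboxylic acid in place of its nitro group, where both ends of the pair might give plain numbers.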